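Moving a nitro group on a curcumin-like pyrazole conjugate

The source may hold more compounds than are shown below. What is called first, only, known or untested is meant among the compounds shown, and "the series" means these compounds.

Measured compounds:
- compound 1 `O=Cc1cn(-c2ccccc2)nc1-c1ccc([N+](=O)[O-])cc1`: 80%
- compound 2 `O=Cc1cn(-c2ccccc2)nc1-c1ccccc1O`: 79%
- compound 3 `COc1cc(/C=C/C(=O)C(=Cc2cn(-c3ccccc3)nc2-c2ccc([N+](=O)[O-])cc2)C(=O)/C=C/c2ccc(O)c(OC)c2)ccc1O`: 90%

All three were tested in a functional assay on MCF7 cells (Homo sapiens) for antiproliferative activity, read by MTT assay, with a stated time of 24 h, tested at 1 ug/mL; on this read-out higher numbers stand for a weaker effect at the one concentration tested and lower numbers for a stronger effect. Compound 1 gives 80% in this assay, compound 2 gives 79%, and compound 3 gives 90%. Compound 3 therefore stands highest of the three numbers. Its nearest neighbour is compound 1, whose number lies within the usual scatter of compound 3, so no order can be drawn between them. Its furthest neighbour is compound 2, whose number lies beyond the scatter, so compound 3 shows a weaker effect at the tested concentration than compound 2.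

Compound 4 `COc1cc(/C=C/C(=O)C(=Cc2cn(-c3ccccc3)nc2-c2cccc([N+](=O)[O-])c2)C(=O)/C=C/c2ccc(O)c(OC)c2)ccc1O` has not yet been measured. It differs from compound 3 in one place only, with the same atoms joined differently: 3-nitrophenyl in place of 4-nitrophenyl on an aromatic carbon. The nitro group thus moves around the phenyl ring while everything else stays the same.

Going by the values given here, no pair of measured compounds differs in just one place, so there is no measured step to lean on. Given that compound 3 gives 90%, the step of a number 2 percentage points lower from compound 3 to compound 4 (within the scatter) is expected to be none beyond the scatter. Compound 4 is thus estimated at 88%, with a range from 76% to 100%.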

Compound 4, a percentage reported as activity, at one concentration (the size of the read-out at that concentration, not a potency): 70%
Compound 4: middle estimate off by 18 percentage points, on the high side; the whole stated range lies above it.
By their numbers in this assay, from the lowest: compounds 4, 2, 1 and 3 (each within the scatter of the next, the first and the last beyond it).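

In this assay, replacing 4-nitrophenyl with 3-nitrophenyl gives a number 20 percentage points lower from compound 3 to compound 4 (beyond the scatter), and a lower number here stands for a stronger effect at the one concentration tested. Going by these compounds alone, this is the first step that isolates a single change, and it shows that the place of the nitro group on this phenyl ring can alter the read-out even though the rest of the molecule stays the same. The atoms, the double bonds and the counted hydrogen-bond donors and acceptors of the two groups are identical, and nothing measured here accounts for the difference in their effect.

The compounds shown leave open whether an amine or a carboxylic acid in place of the nitro group on this phenyl ring would also change the number, so this step speaks only for the move from 4-nitrophenyl to 3-nitrophenyl. From the compounds shown here alone, it also remains open whether the gap between this pair would hold at other concentrations, since a read-out at a single concentration gives the size of an effect there and not a potency.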